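The source may report more compounds than this note shows. Statements on the series, on what has been measured and on what is new or still open speak of the compounds shown alone.

The series shares one core, seen in compound 1 `N#CC1=C(N)N(c2ccc(S(N)(=O)=O)cc2)C2=C(C(=O)CCC2)C1c1ccccc1`. In a functional assay on Ehrlich cells (Mus musculus) for antiproliferative activity, read by trypan blue exclusion, with a stated time of 2 h, tested at 10 ug/mL (on this read-out higher numbers stand for a stronger effect at the one concentration tested and lower numbers for a weaker effect), compound 1 gives 10%. Compound 2 `Cc1ccc(C2C(C#N)=C(N)N(c3ccc(S(N)(=O)=O)cc3)C3=C2C(=O)CCC3)cc1` gives 30% in this assay, and compound 3 `N#CC1=C(N)N(c2ccc(S(N)(=O)=O)cc2)C2=C(C(=O)CCC2)C1c1ccc(O)cc1` gives 90%. Compound 3 stands highest of the three numbers: the step of a number 80 percentage points higher from compound 1 to compound 3 (beyond the scatter) and the step of a number 60 percentage points higher from compound 2 to compound 3 (beyond the scatter) both lie beyond the scatter, whereas a number 20 percentage points higher from compound 1 to compound 2 (beyond the scatter) is only modest.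

Compound 4 `N#CC1=C(N)N(c2ccc(S(N)(=O)=O)cc2)C2=C(C(=O)CCC2)C1/C=C/c1ccccc1` is not yet measured in this assay. Its change from compound 3 is 2-phenylethenyl in place of 4-hydroxyphenyl on a saturated ring carbon. Among the measured compounds shown here, no measured step introduces a 2-phenylethenyl group, so nothing directly reports what that group does. For the measured compounds named here, the steps that bear on the change are those in which the hydroxy is the difference, and compound 4 carries no hydroxy; compound 3 sits well above compound 1 because a number 80 percentage points higher from compound 1 to compound 3 (beyond the scatter) is large, and above compound 2 because a number 60 percentage points higher from compound 2 to compound 3 (beyond the scatter) is large. A downward step is therefore expected, a number 65 percentage points lower from compound 3 to compound 4 (beyond the scatter), back toward the numbers seen without the hydroxy. Compound 4 is estimated at 25%, with a range from 5% to 55%.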

Compound 4, a percentage reported as activity, at one concentration (the size of the read-out at that concentration, not a potency): 2%
The estimate for compound 4 lay 23 percentage points above the measured number, and the stated range ends above it.
By their numbers in this assay, from the lowest: compounds 4 and 1 (each within the scatter of the next); then compound 2; then compound 3.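

In this assay, this saturated ring carbon now carries something other than a directly attached aryl group, yet 2-phenylethenyl and phenyl cannot be told apart: a number 8 percentage points lower from compound 1 to compound 4 (within the scatter). The comparison with the substituted phenyl groups separates them: the step is modest against 4-methylphenyl, a number 28 percentage points lower from compound 2 to compound 4 (beyond the scatter), and large against 4-hydroxyphenyl, a number 88 percentage points lower from compound 3 to compound 4 (beyond the scatter), so an unsubstituted aromatic ring carried by the double bond does not reproduce the number of compound 3. No measurement here accounts for these steps.

On these data alone, whether a hydroxy on the aromatic ring of 2-phenylethenyl would recover the lost number remains open. Also open, as far as these compounds go, is whether an amine or a carboxylic acid could stand in place of the hydroxy of compound 3, and what a longer saturated chain would give at this ring carbon.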